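The source may report more compounds than this note shows. Statements on the series, on what has been measured and on what is new or still open speak of the compounds shown alone.

Compound 2 (`N=C(NCCCc1c[nH]cn1)NCCC(c1cccc(F)c1)c1ccccn1`) gives the higher of the two numbers recorded so far in a functional assay on muscle tissue for agonist activity at histamine H2 receptor (Cavia porcellus) (a lower number here means a less potent compound, a higher number a more potent compound, by a factor of ten per unit of this negative logarithm), namely 7.79. Among the compounds with values here, the only other measured compound, compound 1 (`N=C(NCCCc1c[nH]cn1)NCCC(c1ccccc1)c1ccccn1`), gives 7.37 in this assay. Within the data shown here, the single step on record, a number 0.42 log units higher from compound 1 to compound 2 (beyond the scatter), is the one that bears on what follows. Compound 3 (`N=C(NCCCc1c[nH]cn1)NCCC(c1cccc(C(F)(F)F)c1)c1ccccn1`) differs from compound 2 by trifluoromethyl in place of fluoro on an aromatic carbon. Among the measured compounds shown here, no measured step shows what a change of this kind does here, so compound 3 is expected to move by about a number 0.01 log units higher from compound 2 to compound 3 (within the scatter), that is, not beyond the scatter. The estimate for compound 3 is 7.8, between 7.2 and 8.4.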

Compound 3, negative logarithm of the half-maximal effective concentration: 7.44
Beside the measured number, compound 3's estimate is 0.36 log units above it; the measured number falls inside the stated range.
By their numbers in this assay, from the lowest: compounds 1 and 3 (each within the scatter of the next); then compound 2.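

At this place, meta to a large group, the rise seen with fluoro does not carry over to trifluoromethyl: this assay shows a number 0.35 log units lower from compound 2 to compound 3 (beyond the scatter). Set against hydrogen, trifluoromethyl gives a number 0.07 log units higher from compound 1 to compound 3 (within the scatter), so a substituent here does not raise the number simply by being present. Nothing available accounts for the difference between fluoro and trifluoromethyl at this place.
On these data alone, how chloro, methyl or methoxy at this place would compare with fluoro remains open. So does whether fluoro and trifluoromethyl would give the same steps on another carbon of this ring.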